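A few compounds are considered here, and "the series" means these few. Any claim that something is new, unique, unknown or untested is made for them only; others in the source may bear on it.

Measured compounds:
Compound 1 `COc1ccc(C(=O)c2sc3nc(-c4cccs4)ccc3c2N)cc1` gives 0.77 ug/mL in a functional assay on WI-38 VA13 cells (Homo sapiens) for cytotoxicity; a higher number here means that more compound is needed for the effect, a lower number that less compound is needed.
Compound 2 `COc1cccc(C(=O)c2sc3nc(-c4cccs4)ccc3c2N)c1` gives 0.03 ug/mL in this assay.
Compound 3 `Nc1c(C(=O)c2cccc(F)c2)sc2nc(-c3cccs3)ccc12` gives 0.025 ug/mL in this assay.

Compound 3 has the lowest number of the three. Its nearest neighbour is compound 2, and the step of a 1.2-fold lower number from compound 2 to compound 3 (0.08 log units; within the scatter) lies within the scatter, so the two cannot be ordered. Compound 1 is the furthest, with a large step of a 31-fold lower number from compound 1 to compound 3 (1.49 log units; beyond the scatter); the step of a 26-fold lower number from compound 1 to compound 2 (1.41 log units; beyond the scatter) is of the same kind.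

Compound 4 `Nc1c(C(=O)c2cccc([N+](=O)[O-])c2)sc2nc(-c3cccs3)ccc12` is not yet measured. It differs from compound 3 by nitro in place of fluoro on an aromatic carbon. Within the data shown here, only one measured step bears on this: the exchange from compound 2 to compound 3, which replaced a substituent on this same aromatic carbon and stayed within the scatter. The two large steps concern the position of the substituent, not its identity, and do not apply here. On that basis the expectation for this assay is a step that stays within the scatter, a 1.2-fold higher number from compound 3 to compound 4 (0.08 log units; within the scatter). Compound 4 is therefore expected to give about 0.03 ug/mL, with a range from 0.01 ug/mL to 0.1 ug/mL.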

Compound 4, half-maximal effective concentration: 0.15 ug/mL
Compound 4: middle estimate off by 5.0-fold (0.70 log units), on the low side; the measured number lies above the stated range.
By their numbers in this assay, from the lowest: compounds 3 and 2 (each within the scatter of the next); then compound 4; then compound 1.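

At this aromatic carbon, meta to a large group, the earlier exchange had suggested that the choice of substituent might make little difference in this assay, since fluoro and methoxy could not be told apart. Nitro shows that the position is not indifferent to what it carries: in place of fluoro it gives a 6.0-fold higher number from compound 3 to compound 4 (0.78 log units; beyond the scatter), and in place of methoxy it gives a 5.0-fold higher number from compound 2 to compound 4 (0.70 log units; beyond the scatter), both steps beyond the scatter. Nothing available explains why nitro departs from the other two groups.

Among these compounds, with only three groups at this carbon, it remains open whether an amine, a carboxylic acid or a nitrile would stay with fluoro and methoxy or move with nitro. Also open, as far as these compounds go, is whether nitro would produce a similar step on another carbon of the same ring.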